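Nitro substitution in a small set of aryl sulfonamides

The source may hold more compounds than are shown below. What is called first, only, known or untested is meant among the compounds shown, and "the series" means these compounds.

Compound 1 `O=S(=O)(Nc1ccccc1)c1ccc(Br)cc1` and compound 2 `O=[N+]([O-])c1cccc(NS(=O)(=O)c2ccc(Br)cc2)c1` differ only in that compound 2 carries a nitro in place of hydrogen on an aromatic carbon. In an ADME assay, compound 1 gives 8.5 and compound 2 gives 7.42, so the change made a drop of a number 1.08 log units lower from compound 1 to compound 2 (beyond the scatter). Compound 3 `O=S(=O)(Nc1ccc(Cl)cc1)c1ccccc1` sits on a different core; how it differs from compound 1 is not broken down here. In this assay compound 3 gives 8.75, within the scatter of compound 1. Compound 4 `O=[N+]([O-])c1cccc(S(=O)(=O)Nc2ccc(Cl)cc2)c1` carries the same change relative to compound 3, a nitro in place of hydrogen on an aromatic carbon, and is still to be measured in this assay. Within the data shown here, a step of about the same size is expected from compound 3 to compound 4, a number 1.05 log units lower from compound 3 to compound 4 (beyond the scatter), because the single observed step of a number 1.08 log units lower from compound 1 to compound 2 (beyond the scatter) was large and beyond the scatter. Compound 4 is therefore estimated at 7.7, between 7.2 and 8.2.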

Compound 4, acid dissociation constant: 7.19
Compound 4: middle estimate off by 0.51 log units, on the high side; the measured number lies below the stated range.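

In this assay, the nitro in place of hydrogen on an aromatic carbon again comes with a number 1.56 log units lower from compound 3 to compound 4 (beyond the scatter), so the direction of the change carries over to the second core. Among these compounds, the size does not carry over unchanged: the same change on two cores in this assay, a number 1.08 log units lower (beyond the scatter) from compound 1 to compound 2 and a number 1.56 log units lower (beyond the scatter) from compound 3 to compound 4, 0.48 log units apart, beyond the scatter of two such steps With only two cores, these results do not show what sets the size of the step or how large it would be on a further core.

Still open, going by these compounds, is whether an amine or a carboxylic acid in place of the same hydrogen would move the number in the same direction. Also open, on these data alone, is whether the nitro step would stay near either size on a core outside these four compounds.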